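A Single Ring Swap in a Weak Series

The compounds below may be only part of what the source reports. "The series", "measured", "known", "first", "only" and "open" are said of these compounds alone.

Of the compounds shown here, three that share one core have been tested so far. In a functional assay on A549 cells (Homo sapiens) for cytotoxicity, read by MTT assay, with a stated time of 72 h (a lower number here means a stronger inhibitor, a higher number a weaker inhibitor), compound 1 `COc1cccc(/C=C2\CCC/C(=C\c3cc(Cl)cc(Cl)c3)C2=O)c1OC` gives 12500 nM as a true number. Compound 2 `COc1ccc(/C=C2\CCC/C(=C\c3cccc(OC)c3OC)C2=O)c(OC)c1` reads > 20000 nM and this is a limit of the assay, not a number. Compound 3 `COc1ccc(/C=C2\CCC/C(=C\c3ccccc3Cl)C2=O)cc1OC` stands at > 20000 nM and this is also only a limit. Compound 4 `COc1ccc(/C=C2\CCC/C(=C\c3cccc(Br)c3)C2=O)cc1OC` differs from compound 3 in one group, with 3-bromophenyl in place of 2-chlorophenyl on a double-bonded chain carbon bound to a double-bonded ring carbon. Among the compounds with values here, no tested pair shows a comparable swap, so the step has to be judged without a direct guide. In this assay the estimated move is small (an at least 1.1-fold lower number from compound 3 to compound 4 (0.04 log units; that floor lies within the scatter)) with no firm direction. Compound 4 is expected near 18000 nM with an estimated range from 8000 nM to 40000 nM and it may well return only a limit.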

Compound 4, half-maximal inhibitory concentration: 12800 nM
Estimate against measurement, compound 4: 1.4-fold (0.15 log units) above; measured number inside the range.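

In this assay, compound 4 returns a true number, while compound 3 returned only a limit, so this position on a double-bonded chain carbon bound to a double-bonded ring carbon now has a first readable swap. Putting 3-bromophenyl in place of 2-chlorophenyl gives an at least 1.5-fold lower number from compound 3 to compound 4 (0.19 log units; that floor lies within the scatter). Only a floor can be stated because compound 3 sits at a limit: the limit of > 20000 nM in this assay, at which 2 of the 4 values shown sit.

The swap changes both the halogen and where it sits on the ring, and the compounds shown do not separate the two. As far as these compounds go, how a group carrying an amine or a carboxylic acid would read here also stays open.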